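Two Chlorines in Place of One Fluorine

The source may report more compounds than this note shows. Statements on the series, on what has been measured and on what is new or still open speak of the compounds shown alone.

Measured compounds:
compound 1, `CC1(c2ccccc2)CC(=O)N(CC(=O)N2CCN(c3cccc(Cl)c3Cl)CC2)C1=O`: "not active" (no number reported)
compound 2, `CC1(c2ccccc2)CC(=O)N(CC(=O)N2CCN(c3ccc(F)cc3)CC2)C1=O`: 100 mg/kg

Of the compounds shown here, two have been tested in a functional assay on the whole organism (strain CD-1) with Mus musculus as the target, in the maximal electroshock model, with a stated time of 2 h; on this read-out higher numbers stand for an effect only at larger amounts of compound and lower numbers for an effect already at smaller amounts. Compound 1 is recorded as "not active" (no number reported), without any number attached. Going by the values given here, compound 2 therefore holds the only number in this assay, giving 100 mg/kg, and no step between two measured compounds can be drawn from these data.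

Compound 3, `CC1(c2ccccc2)CC(=O)N(CC(=O)N2CCN(c3ccc(Cl)c(Cl)c3)CC2)C1=O`, has not yet been measured. It differs from compound 2 in a single place: 3,4-dichlorophenyl in place of 4-fluorophenyl on an amine nitrogen in a ring.

Among the compounds with values here, no measured pair shows the effect of such a change, so the expectation for compound 3 rests on compound 2 alone. The result for compound 1 gives a hint that a ring carrying two chlorines in this position may fail to show an effect. For that reason compound 3 is expected to need a somewhat larger amount than compound 2, a step of a 2.0-fold higher number from compound 2 to compound 3 (0.30 log units; within the scatter) that lies beyond the usual scatter. Compound 3 is estimated at 200 mg/kg, within a range from 100 mg/kg to 400 mg/kg, with a real chance that only an inactive result is reported.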

Compound 3, minimum effective dose: 300 mg/kg
The estimate for compound 3 lay 1.5-fold (0.18 log units) below the measured number; the range from low to high includes it.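

In this assay, placing 3,4-dichlorophenyl in place of 4-fluorophenyl on an amine nitrogen in a ring gives a 3.0-fold higher number from compound 2 to compound 3 (0.48 log units; beyond the scatter). This first measured pair shows that the group at this position matters: here, the dichlorinated ring is linked to an effect only at a larger amount of compound. It also shows that two chlorines on this ring do not by themselves remove a measurable effect, since compound 3 gives 300 mg/kg, whereas compound 1, which also carries two chlorines on its ring, is recorded as "not active" (no number reported). No measurement shown here explains why the number rises.

As far as these compounds go, this single step changes both the kind of halogen and the number of halogens at once, so the contribution of each remains open. A plain phenyl ring or a phenyl ring bearing a single chlorine would help separate the two, while a methoxy group on the ring would show whether the trend extends beyond halogens.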